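This account rests on a few compounds, and the source may have more. Where it says the series, first, only, none or still open, it means among the compounds named here.

In a functional assay on HeLa cells (Homo sapiens) for inhibition, read by MTT assay, with a stated time of 48 h (on this read-out higher numbers stand for weaker inhibition and lower numbers for stronger inhibition), compound 1 `COc1cc(/C=C/C(=O)NO)ccc1OCC(=O)Nc1ccccc1F` reads 11100 nM. Compound 3 `COc1cc(/C=C/C(=O)Nc2ccccc2N)ccc1OCC(=O)Nc1cc(C(F)(F)F)cc(C(F)(F)F)c1` reads 20800 nM. Compound 2 `COc1cc(/C=C/C(=O)Nc2ccccc2N)ccc1OCC(=O)Nc1cccc(F)c1` reads 28100 nM. Compound 1 and compound 3 stand within the scatter of each other. Compound 1 stands beyond the scatter of compound 2, on the lower side. Compound 4 `COc1cc(/C=C/C(=O)NO)ccc1OCC(=O)Nc1ccc(Br)cc1` carries 4-bromophenyl in place of 2-fluorophenyl on an amide-type nitrogen and otherwise keeps the core of compound 1 unchanged. Among the measured compounds shown here, no measured pair differs at this place alone, so the data give no size for such a step. No step beyond the scatter is expected in this assay in either direction. The estimated change is a 1.1-fold lower number from compound 1 to compound 4 (0.05 log units; within the scatter) and remains an expectation only. Compound 4 is expected at 10000 nM within a range of 4000 nM to 25000 nM on this estimate.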

Compound 4, half-maximal inhibitory concentration: > 100000 nM
Compound 4 ended at the assay's limit (the forecaster's own chance of this, stated with the estimate: 8%); middle value at least 10-fold (1.00 log units) from the limit.
By their numbers in this assay, from the lowest: compounds 1, 3 and 2 (each within the scatter of the next, the first and the last beyond it). At a limit, above all of these: compound 4.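

In this assay compound 4 reads > 100000 nM, which is a limit of the assay and not a number: the limit of > 100000 nM in this assay, at which 1 of the 4 values shown sits.

Among the compounds shown here, putting 4-bromophenyl in place of 2-fluorophenyl on the amide-type nitrogen gives the only single-place step, an at least 9.0-fold higher number from compound 1 to compound 4 (0.95 log units; beyond the scatter). The two groups have matching counts of heavy atoms, hydrogen-bond donors and acceptors, yet this position does not tolerate every aryl group equally.

For the compounds shown here, the one step changes both the halogen and its place on the ring, and these remain unseparated. A plain phenyl or an aminophenyl on the same nitrogen would show how far this position extends.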